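Swapping a Methoxy for a Hydroxy on a Potent Compound

The source may hold more compounds than are shown below. What is called first, only, known or untested is meant among the compounds shown, and "the series" means these compounds.

Measured so far in a functional assay on P388 cells (Mus musculus) for cytotoxicity; a higher number here means a weaker inhibitor, a lower number a stronger inhibitor:
- compound 1 `COc1ccc(C[C@H]2C(=O)N[C@@H](C)C(=O)N(C)[C@H]3Cc4ccc(cc4)Oc4cc(ccc4OC)C[C@@H](C(=O)N[C@H](C)C(=O)N[C@@H](CC=O)C(=O)N2C)N(C)C3=O)cc1`: 33.9 nM
- compound 2 `COc1ccc(C[C@H]2C(=S)N[C@@H](C)C(=O)N(C)[C@H]3Cc4ccc(cc4)Oc4cc(ccc4OC)C[C@@H](C(=O)N[C@H](C)C(=O)N[C@@H](C)C(=O)N2C)N(C)C3=O)cc1`: 0.741 nM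

Of these two numbers, compound 2 at 0.741 nM has the lower, making it the stronger inhibitor, and the gap to compound 1 at 33.9 nM lies beyond the scatter. Compound 3 `COc1ccc(C[C@H]2C(=S)N[C@@H](C)C(=O)N(C)[C@H]3Cc4ccc(cc4)Oc4cc(ccc4O)C[C@@H](C(=O)N[C@H](C)C(=O)N[C@@H](C)C(=O)N2C)N(C)C3=O)cc1` alters compound 2 in one place: hydrogen in place of methyl on an oxygen on an aromatic ring, methoxy to hydroxy. Within the data shown here, no measured pair shows this change, so the expectation is uncertain. The estimated step of a 1.6-fold higher number from compound 2 to compound 3 (0.21 log units; within the scatter) is slightly towards a higher number in this assay, but none beyond the scatter is expected. For compound 3 the expected value is 1.2 nM, with an estimated range of 0.3 nM to 5 nM.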

Compound 3, half-maximal inhibitory concentration: 1.15 nM
Beside the measured number, compound 3's estimate is 1.0-fold (0.02 log units) above it, within the range that was stated.
By their numbers in this assay, from the lowest: compounds 2 and 3 (each within the scatter of the next); then compound 1.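

In this assay the swap of methoxy to hydroxy, on an oxygen on an aromatic ring, stays within the scatter (a 1.6-fold higher number from compound 2 to compound 3 (0.19 log units; within the scatter)). The earlier compounds shown here did not test this position, and this pair shows that the methyl on this oxygen can give way to hydrogen with no measurable loss in this assay. Nothing available explains this result. Going by these compounds, whether a longer chain on this oxygen, or an amine in place of the hydroxy, would be tolerated stays open. So does the same swap at the other methoxy.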